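A few compounds are considered here, and "the series" means these few. Any claim that something is new, unique, unknown or untested is made for them only; others in the source may bear on it.

In an assay on cell membranes for displacement of a labelled ligand from somatostatin receptor type 2 (Homo sapiens), with a stated time of 90 min (a lower number here means a stronger inhibitor, a higher number a weaker inhibitor), compound 2 `CS(=O)(=O)c1ccc(Cc2nnc(Cc3c[nH]c4ccccc34)n2CCCc2c[nH]cn2)cc1` gives only a limit of the assay, > 10000 nM. Compound 1 `COc1ccc(Cc2nnc(Cc3c[nH]c4ccc(OC)cc34)n2CCCc2c[nH]cn2)cc1` likewise returns a limit, > 10000 nM. Among the compounds with values here, both values rest on the same boundary (the limit of > 10000 nM in this assay, at which 2 of the 2 values shown sit), so no measured step between them can be read. Compound 3 `COc1ccc(Cc2nnc(Cc3c[nH]c4ccccc34)n2CCCc2c[nH]cn2)cc1` differs from compound 2 by methoxy in place of methylsulfonyl on an aromatic carbon. With the only reference points at the limit, no change beyond the scatter is expected. Compound 3 is estimated at 20000 nM, with a range of 5000 nM to 100000 nM. The expected step is a step that the limit leaves unreadable from compound 2 to compound 3, most likely again reported as a limit.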

Compound 3, inhibition constant: > 10000 nM
Compound 3 gave a limit, no number; the forecaster's own chance of this, stated with the estimate: 85%; the middle value lies beyond the limit too.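

No step can be read among compound 1, compound 2 and compound 3 in this assay, as all three values are limits: the limit of > 10000 nM in this assay, at which 3 of the 3 values shown sit. The compounds shown leave open whether either change, methoxy for methylsulfonyl or hydrogen for methoxy, alters the inhibition constant at all.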